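The source may hold more compounds than are shown below. What is called first, only, known or untested is meant among the compounds shown, and "the series" means these compounds.

Measured so far:
- compound 1, `COc1ccc(-c2cc(C(C)=O)c3[nH]c(-c4ccccc4)cc3c2)cc1` — in a functional assay on HeLa cells (Homo sapiens) for cytotoxicity, read by MTT assay, with a stated time of 2 days (on this read-out lower numbers stand for higher toxicity in this test and higher numbers for lower toxicity in this test), compound 1 gives 15500 nM
- compound 2, `CC(=O)c1cc(-c2ccc(F)cc2)cc2cc(-c3ccc(F)cc3)[nH]c12` — in this assay compound 2 gives 13800 nM

Of the compounds shown here, two have been measured. Compound 2 has the lowest of the two numbers in this assay, but its nearest neighbour, compound 1, sits within the scatter of it, so the two values show no difference that can be read as real.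

The unmeasured compound 3, `COc1ccc(-c2cc(C(C)=O)c3[nH]c(-c4ccc(F)cc4)cc3c2)cc1`, is made from compound 2 by a single change: methoxy in place of fluoro on an aromatic carbon. It thereby carries a 4-methoxyphenyl group like compound 1 and a 4-fluorophenyl group like compound 2. Within the data shown here, no step between measured compounds covers this exact change, so the expectation rests on the two values shown. Since compound 1 and compound 2 lie within the scatter of each other, the step of a 1.1-fold higher number from compound 2 to compound 3 (0.02 log units; within the scatter) is expected to be no larger than the scatter, in no particular direction. Compound 3 is therefore expected to give about 14500 nM in this assay, within a range from 7000 nM to 30000 nM.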

Compound 3, concentration lethal to 50% of the cells: 9460 nM
For compound 3 the middle estimate is 1.5-fold (0.19 log units) above the measured one; the range from low to high includes it.
By their numbers in this assay, from the lowest: compounds 3, 2 and 1 (each within the scatter of the next).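

In this assay, the step of a 1.5-fold lower number from compound 2 to compound 3 (0.16 log units; within the scatter) lies within the scatter, so 4-fluorophenyl and 4-methoxyphenyl at this place, para to a large group, cannot be told apart by this read-out. The step of a 1.6-fold lower number from compound 1 to compound 3 (0.21 log units; within the scatter) is also within the scatter, which means that fluoro in place of hydrogen on the other aromatic ring likewise has no effect that can be read here, and compound 3 is what allows each of these two changes to be read on its own, since compound 1 and compound 2 differ from each other in more than one place. Nothing available explains these values or bears on them.

Among these compounds, the three compounds therefore show only that these small changes on the two aromatic rings leave the values of this assay within the scatter of one another, and they give no direction for either change. Open, going by these compounds, is whether a group of another kind at this aromatic carbon, such as an amine, a carboxylic acid or a longer chain like butoxy, would give a step beyond the scatter.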